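Growth inhibition notes: compound 3 to compound 4

A few compounds are considered here, and "the series" means these few. Any claim that something is new, unique, unknown or untested is made for them only; others in the source may bear on it.

Among the compounds with values here, in a functional assay on T47D cells (Homo sapiens) for inhibition, read by CCK-8 assay, with a stated time of 72 h, tested at 1 uM (on this read-out higher numbers stand for more inhibition of growth at the one concentration tested and lower numbers for less inhibition of growth), compound 3 (`CN(C)C(=O)c1cc2cnc(Nc3ccc(NC(=O)C4(C(=O)Nc5cccc(F)c5)CC4)cc3)nc2n1C1CCCC1`) gives -3.2%, the lowest of the three numbers so far. Compound 2 (`CN(C)C(=O)c1cc2cnc(Nc3ccc(N)cn3)nc2n1C1CCCC1`) gives 18.8%, and compound 1 (`CN(C)C(=O)c1cc2cnc(Nc3ccc(NC(=O)C4(C(=O)Nc5ccc(F)cc5)CC4)cc3)nc2n1C1CCCC1`) gives 74.7%, both clearly higher.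

The next structure is compound 4 (`Cc1ccc(NC(=O)C2(C(=O)Nc3ccc(Nc4ncc5cc(C(=O)N(C)C)n(C6CCCC6)c5n4)cc3)CC2)cc1`), which has 4-methylphenyl in place of 3-fluorophenyl on an amide-type nitrogen.

Within the data shown here, only one measured step bears on this change: a number 77.9 percentage points lower from compound 1 to compound 3 (beyond the scatter). That step is large and beyond the scatter, and it comes with 3-fluorophenyl in place of 4-fluorophenyl at the same place. Among the measured compounds shown here, compound 2 differs from compound 3 in more than one place and offers no matched step.

Compound 4 shares with compound 1 a phenyl group named with the 4 label, but it carries methyl instead of fluorine. For the measured compounds named here, no measured compound has 4-methylphenyl, and the evidence is a single pair. The expectation therefore recovers most, though not all, of the gap seen with compound 1 at 74.7%, with wide uncertainty.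

The expected step is a number 58.2 percentage points higher from compound 3 to compound 4 (beyond the scatter), upward and beyond the scatter. For compound 4 the estimated value is 55%, with an expected range of 20% to 85%.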

Compound 4, percent growth inhibition at one concentration: 47.9%
Compound 4: the middle estimate sits 7.1 percentage points above what was measured; the range from low to high includes it.
By their numbers in this assay, from the lowest: compound 3; then compound 2; then compound 4; then compound 1.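

Here the result is a number 51.1 percentage points higher from compound 3 to compound 4 (beyond the scatter) in this assay and this shows that the low number of compound 3 is not shared by every substituted phenyl on this amide-type nitrogen. Between the two phenyl groups that carry the 4 label, methyl in place of fluoro on an aromatic carbon still changes the reading: the result is a number 26.8 percentage points lower from compound 1 to compound 4 (beyond the scatter) and this step is modest, where the other two changes at this place are large. No measurement is available that accounts for either step.

Whether the 3 label itself goes with the low number or only the fluorine there remains open, since 3-methylphenyl does not appear among the compounds shown, and it is equally unclear how a methoxy group, a chlorine or an amine on this phenyl would read. The compounds shown also leave open whether the order of the three phenyl groups on this nitrogen would hold at concentrations other than the single one tested.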